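Replacing one benzyl ester by methyl in compound 2

A few compounds are considered here, and "the series" means these few. Any claim that something is new, unique, unknown or untested is made for them only; others in the source may bear on it.

Working notes on a set of dihydropyridine esters sharing one core, tested in an assay on isolated protein (strain albino) for antagonist activity at Voltage-dependent L-type calcium channel subunit alpha-1C (Cavia porcellus); a lower number here means a stronger inhibitor, a higher number a weaker inhibitor. Compound 1 `CSc1ncc(C2C(C(=O)OC(C)(C)C)=C(C)NC(C)=C2C(=O)OC(C)(C)C)n1Nc1ccccc1` gives 121 nM in this assay. Compound 2 `CSc1ncc(C2C(C(=O)OCc3ccccc3)=C(C)NC(C)=C2C(=O)OCc2ccccc2)n1Nc1ccccc1` gives 1.49 nM in this assay, the lowest number of the three. Compound 3 `CSc1ncc(C2C(C(=O)OCCCc3ccccc3)=C(C)NC(C)=C2C(=O)OCCCc2ccccc2)n1Nc1ccccc1` gives 3.15 nM in this assay, which stands beyond the scatter from compound 2, as does the much higher number of compound 1. All three carry the same ester group on both sides of the core.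

Compound 4 `COC(=O)C1=C(C)NC(C)=C(C(=O)OCc2ccccc2)C1c1cnc(SC)n1Nc1ccccc1` has not yet been measured in this assay. It differs from compound 2 in one place: hydrogen in place of phenyl on a saturated chain carbon bound to an oxygen next to a carbonyl group. One of the two benzyl esters is thus cut back to a methyl ester while the other is kept. Among the compounds with values here, the set so far contains no pair differing in a single ester alone, so no measured step can be quoted for this change. Since the ester groups move this assay strongly, as the gap between compound 1 and compound 2 shows, a moderate loss is expected from the step of a 4.0-fold higher number from compound 2 to compound 4 (0.60 log units; beyond the scatter), beyond the scatter but well short of the gap to compound 1. Compound 4 is therefore estimated at 6 nM in this assay, with a range from 1.5 nM to 25 nM.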

Compound 4, half-maximal inhibitory concentration: 2.21 nM
For compound 4 the middle estimate is 2.7-fold (0.43 log units) above the measured one, within the range that was stated.
By their numbers in this assay, from the lowest: compounds 2, 4 and 3 (each within the scatter of the next, the first and the last beyond it); then compound 1.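

In this assay, within the data shown here, this is the first step that changes one ester alone, and a 1.5-fold higher number from compound 2 to compound 4 (0.17 log units; within the scatter) lies within the scatter. Among these compounds, at this saturated chain carbon bound to an oxygen next to a carbonyl group, hydrogen can therefore stand in place of phenyl without a readable change while the other benzyl ester is kept, something the earlier compounds could not show because their two esters are always identical. Nothing at hand gives a reason for this result.

Going by these compounds, it remains open whether methyl esters on both sides would stay in the same range, which would show whether the kept benzyl ester is needed. Also open, on these data alone, is how this position would respond to a longer chain, or to a chain ending in an amine or a carboxylic acid.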